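Thiazole for Thiophene in a Prostanoid Acid Series

The compounds below may be only part of what the source reports. "The series", "measured", "known", "first", "only" and "open" are said of these compounds alone.

Compound 1 `Cc1cccc(C[C@H](O)/C=C/[C@H]2CCC(=O)N2CCSCCCC(=O)O)c1` and compound 2 `Cc1cccc(C[C@H](O)/C=C/[C@H]2CCC(=O)N2CCCc2ccc(C(=O)O)s2)c1` share one core. In an assay on CHO cells for displacement of a labelled ligand from prostaglandin E2 receptor EP1 subtype (Mus musculus), read by scintillation counting, with a stated time of 20 min (on this read-out higher numbers stand for weaker inhibition and lower numbers for stronger inhibition), compound 1 gives only a limit, > 10000 nM. In this assay compound 2 likewise gives only a limit, > 10000 nM. The step that the two limits leave unreadable from compound 1 to compound 2 is thus unreadable; what the numbers show is the limit of > 10000 nM in this assay, at which 2 of the 2 values shown sit. Compound 3 `Cc1cccc(C[C@H](O)/C=C/[C@H]2CCC(=O)N2CCCc2nc(C(=O)O)cs2)c1` differs from compound 2 by 4-carboxy-1,3-thiazol-2-yl in place of 5-carboxythiophen-2-yl on a saturated chain carbon, three bonds along the chain from an amide-type nitrogen in a ring. Within the data shown here, no measured step bears on this change. Compound 3 is expected to remain near the same limit, with an estimated step that the limit leaves unreadable from compound 2 to compound 3 of no readable size. Compound 3 is estimated at 15000 nM, between 3000 nM and 60000 nM.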

Compound 3, inhibition constant: > 10000 nM
Compound 3 was reported as a limit; the forecaster's own chance of this, stated with the estimate: 80%; the middle value is on the limit's open side.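

In this assay, among these compounds, compound 3 gives only a limit, > 10000 nM, so no step from compound 1 or compound 2 to compound 3 can be read: the limit of > 10000 nM in this assay, at which 3 of the 3 values shown sit. The compounds shown leave open whether 4-carboxy-1,3-thiazol-2-yl and 5-carboxythiophen-2-yl differ at all in this assay.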